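Methyl on the benzoyl ring of a chloro-benzocycloheptene hydrazone

The source may hold more compounds than are shown below. What is called first, only, known or untested is meant among the compounds shown, and "the series" means these compounds.

Compound 1 `O=C(N/N=C\C1=C(Cl)c2ccccc2CCC1)C1=C(Cl)c2ccccc2CCC1`: 1000 nM
Compound 2 `COc1cc(/C=N\NC(=O)C2=C(Cl)c3cc(C)c(C)cc3CCC2)cc(OC)c1OC`: 21000 nM
Compound 3 `O=C(N/N=C/C1=C(Cl)c2ccccc2CCC1)c1ccccc1`: > 100000 nM

In a functional assay on HeLa cells (Homo sapiens) for inhibition, read by sulforhodamine B assay, with a stated time of 48 h (a higher number here means a weaker inhibitor of growth, a lower number a stronger inhibitor of growth), compound 1 gives 1000 nM and compound 2 gives 21000 nM. For compound 3 the result > 100000 nM is a limit of this assay, not a number. Among the compounds with values here, compound 3 therefore stands at the weak end of the three values shown, at the limit of > 100000 nM in this assay, at which 1 of the 3 values shown sits, and no step to it can be sized. Compound 4 `Cc1ccc(C(=O)N/N=C/C2=C(Cl)c3ccccc3CCC2)cc1` differs from compound 3 by methyl in place of hydrogen on an aromatic carbon. From a starting point at a limit, the step is expected to stay within the scatter or remain unmeasurable, with the outcome for compound 4 expected at 100000 nM, between 30000 nM and 300000 nM. The step is estimated as a number no higher from compound 3 to compound 4 (the limit leaves the size open).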

Compound 4, concentration for 50% growth inhibition: 300 nM
Compound 4: the middle estimate sits 330-fold (2.52 log units) above what was measured, outside the stated range (below it).
By their numbers in this assay, from the lowest: compound 4; then compound 1; then compound 2. At a limit, above all of these: compound 3.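

In this assay, the change from phenyl to 4-methylphenyl gives an at least 330-fold lower number from compound 3 to compound 4 (2.52 log units; beyond the scatter). At this position, on an aromatic carbon para to a large group, methyl in place of hydrogen thus separates a compound with only a limit from one with a measured number. The result for compound 3 is a limit, so the full size of the step stays open: the limit of > 100000 nM in this assay, at which 1 of the 4 values shown sits.

What the compounds shown leave open is whether methyl itself is required here. An ethyl, a methoxy, a chlorine or an amine at this position could give a different result.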